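A Second Nitrile on an Amide Cytotoxicity Series

A few compounds are considered here, and "the series" means these few. Any claim that something is new, unique, unknown or untested is made for them only; others in the source may bear on it.

Three compounds have values in a functional assay on HL-60 cells (Homo sapiens) for cytotoxicity, read by luminescence and CellTiter-Glo, with a stated time of 3 days; on this read-out lower numbers stand for stronger inhibition and higher numbers for weaker inhibition:
Compound 1, `N#Cc1cccc(NC(=O)c2cc(F)ccc2O)c1`, gives 7750 nM.
Compound 2, `O=C(Nc1ccccc1)c1cc(F)ccc1O`, reaches only a limit of the assay, > 10000 nM.
Compound 3, `N#Cc1ccc(NC(=O)c2ccc3cccnc3c2O)cc1`, gives 370 nM.

Compound 1 and compound 2 share one core, and compound 1 carries the change (cyano in place of hydrogen on an aromatic carbon). The step of an at least 1.2-fold lower number from compound 2 to compound 1 (0.11 log units; that floor lies within the scatter) starts from the limit (the limit of > 10000 nM in this assay, at which 1 of the 3 values shown sits), so only its floor is known, and that floor lies within the scatter. Compound 3 rests on a different core; the difference between the two cores is not broken down here. Of the two numbers, compound 3 gives the lower one, well beyond the scatter of compound 1.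

Compound 4, `N#Cc1ccc(NC(=O)c2ccc3cccnc3c2O)c(C#N)c1`, has not been measured. It differs from compound 3 by cyano in place of hydrogen on an aromatic carbon. This is the same kind of change as from compound 2 to compound 1, not the same: there the cyano entered meta to a large group, here it enters ortho to a large group and meta to a cyano group. Among the compounds with values here, since the one measured example of this kind gave only a floor within the scatter, a small step is expected here, a 1.2-fold lower number from compound 3 to compound 4 (0.09 log units; within the scatter). Compound 4 is therefore estimated at 300 nM, between 120 nM and 900 nM.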

Compound 4, half-maximal inhibitory concentration: 890 nM
The estimate for compound 4 lay 3.0-fold (0.47 log units) below the measured number, within the range that was stated.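

In this assay, the added cyano gives a 2.4-fold higher number from compound 3 to compound 4 (0.38 log units; beyond the scatter), so on the core of compound 3 this change brings a modest loss of inhibition rather than a gain. The change therefore does not carry over as one fixed step between the two cores shown: the same change on two cores in this assay, an at least 1.2-fold lower number (0.11 log units; that floor lies within the scatter) from compound 2 to compound 1 and a 2.4-fold higher number (0.38 log units; beyond the scatter) from compound 3 to compound 4, at least 3.1-fold (0.49 log units) apart, beyond the scatter of two such steps

This does not show how large the earlier step really is or what separates the two pairs, since they differ in core as well as in where the cyano sits, and the value of compound 2 is only a limit of the assay: the limit of > 10000 nM in this assay, at which 1 of the 4 values shown sits.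

From the compounds shown here alone, it remains open how a cyano at the place it takes in compound 4 would behave on the core of compound 1. Also open, going by these compounds, is whether another group at that same place, such as an amine or a carboxylic acid, would give a lower or a higher number than the cyano does.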